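Adding a Methoxy to the Dimethoxyphenyl Arm

The source may hold more compounds than are shown below. What is called first, only, known or untested is meant among the compounds shown, and "the series" means these compounds.

The three compounds examined so far share one core and differ only in the group on a saturated ring carbon. In a functional assay on MDA-MB-231 cells (Homo sapiens) for antiproliferative activity, with a stated time of 48 h (a lower number here means a stronger inhibitor of growth, a higher number a weaker inhibitor of growth), compound 1 `Cc1cc(O)c(C2=NN(c3ccc(S(N)(=O)=O)cc3)C(c3ccccc3O)C2)cc1Cl` gives 6690 nM, compound 2 `Cc1cc(O)c(C2=NN(c3ccc(S(N)(=O)=O)cc3)C(/C=C/c3ccccc3)C2)cc1Cl` gives 16300 nM, and compound 3 `COc1ccc(C2CC(c3cc(Cl)c(C)cc3O)=NN2c2ccc(S(N)(=O)=O)cc2)cc1OC` gives 12500 nM. Compound 3 holds the second highest of the three numbers, and its gaps to both neighbours lie within the scatter: a 1.3-fold lower number from compound 2 to compound 3 (0.12 log units; within the scatter) and a 1.9-fold higher number from compound 1 to compound 3 (0.27 log units; within the scatter). For the measured compounds named here, the only step beyond the scatter is a 2.4-fold higher number from compound 1 to compound 2 (0.39 log units; beyond the scatter).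

Compound 4 `COc1ccc(C2CC(c3cc(Cl)c(C)cc3O)=NN2c2ccc(S(N)(=O)=O)cc2)c(OC)c1OC` differs from compound 3 by methoxy in place of hydrogen on an aromatic carbon. Going by the values given here, none of the measured steps touches this kind of change; all of them exchange the whole pendant group rather than add to it, and the two exchanges that reach compound 3 stayed within the scatter. Among the compounds with values here, no step therefore points in a direction, and for compound 4 the expected step is a 1.0-fold lower number from compound 3 to compound 4 (0.02 log units; within the scatter), not beyond the scatter. In this assay compound 4 is estimated at 12000 nM, with a range from 5000 nM to 30000 nM.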

Compound 4, concentration for total growth inhibition: 5010 nM
Compound 4: middle estimate off by 2.4-fold (0.38 log units), on the high side; the measured number falls inside the stated range.
By their numbers in this assay, from the lowest: compounds 4, 1, 3 and 2 (each within the scatter of the next, the first and the last beyond it).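

Methoxy in place of hydrogen on an aromatic carbon, ortho to a large group, gives a 2.5-fold lower number from compound 3 to compound 4 (0.40 log units; beyond the scatter) in this assay and is the first change here that adds to the pendant group rather than exchanging it whole. The same 2,3,4-trimethoxyphenyl group gives a 3.3-fold lower number from compound 2 to compound 4 (0.51 log units; beyond the scatter) against 2-phenylethenyl, while its exchange for 2-hydroxyphenyl gives a 1.3-fold lower number from compound 1 to compound 4 (0.13 log units; within the scatter) and so does not separate these two groups. No measurement at hand accounts for the effect of this methoxy.

The compounds shown leave open whether an amine, a fluorine atom or an ethoxy group on this same carbon gives a step of similar size. They also leave open whether this methoxy gives such a step without the two methoxy groups already on the ring.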